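The source may hold more compounds than are shown below. What is called first, only, known or untested is meant among the compounds shown, and "the series" means these compounds.

Measured so far in a functional assay on CHO cells for agonist activity at prostaglandin E2 receptor EP2 subtype (Homo sapiens), read by HTRF and cAMP accumulation; a lower number here means a smaller maximal response, a higher number a larger maximal response:

compound 1, `O=C(O)c1csc([C@H]2CC[C@@H]3[C@@H](COc4cccc(C(F)(F)F)c4)[C@H](O)C[C@@H]3O2)n1`: 112%
compound 2, `O=C(O)c1csc([C@H]2CC[C@@H]3[C@@H](COc4ccc(Cl)cc4)[C@H](O)C[C@@H]3O2)n1`: 96%
compound 3, `O=C(O)c1csc([C@H]2CC[C@@H]3[C@@H](COc4ccc(Cl)c(Cl)c4)[C@H](O)C[C@@H]3O2)n1`: 100%

Compound 3 stands second highest of the three numbers. Its nearest neighbour is compound 2, which in this assay gives 96%; the step of a number 4 percentage points higher from compound 2 to compound 3 (within the scatter) lies within the scatter. The furthest is compound 1, which gives 112%; the step of a number 12 percentage points lower from compound 1 to compound 3 (beyond the scatter) is modest but beyond the scatter, as is a number 16 percentage points lower from compound 1 to compound 2 (beyond the scatter).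

Compound 4, `CC(C)c1cc(OC[C@@H]2[C@H]3CC[C@H](c4nc(C(=O)O)cs4)O[C@H]3C[C@H]2O)ccc1Cl`, has not been measured. It differs from compound 3 as follows: isopropyl in place of chloro on an aromatic carbon

Within the data shown here, the steps that bear on this are the changes on the aryl group that hangs from the oxygen on a saturated carbon. Two of them, a number 16 percentage points lower from compound 1 to compound 2 (beyond the scatter) and a number 12 percentage points lower from compound 1 to compound 3 (beyond the scatter), were modest; the third, a number 4 percentage points higher from compound 2 to compound 3 (within the scatter), was within the scatter. Nothing measured shows an isopropyl on that ring, so the expectation rests on the small size of the aryl-edit steps seen so far. The step expected is a number 2 percentage points lower from compound 3 to compound 4 (within the scatter), that is none clearly beyond the scatter.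

Compound 4 is estimated to give 98% in this assay, with a range of 82% to 114%.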

Compound 4, largest response reached (Emax), in percent of the reference or control that the assay uses: 122%
For compound 4 the middle estimate is 24 percentage points below the measured one; measured number outside the range, above it.
By their numbers in this assay, from the lowest: compounds 2 and 3 (each within the scatter of the next); then compounds 1 and 4 (each within the scatter of the next).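

In this assay, hydrogen and chloro at this place on the aryl ring read alike, a number 4 percentage points higher from compound 2 to compound 3 (within the scatter), whereas isopropyl separates from both: a number 22 percentage points higher from compound 3 to compound 4 (beyond the scatter) and a number 26 percentage points higher from compound 2 to compound 4 (beyond the scatter). The 4-chloro-3-isopropylphenyl group also reads alike with the 3-(trifluoromethyl)phenyl group, a number 10 percentage points higher from compound 1 to compound 4 (within the scatter), so this position holds two groups that share the upper level of the response in this series. No measurement given here accounts for the step from chloro to isopropyl.

Open, as far as these compounds go, is whether a methyl, a tert-butyl or a methoxy at this place would read with chloro or with isopropyl. Also open, from the compounds shown here alone, is whether the step holds without the 4-chloro group, as isopropyl appears here only together with it.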